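The source may report more compounds than this note shows. Statements on the series, on what has been measured and on what is new or still open speak of the compounds shown alone.

Measured compounds:

Compound 1 `CC(C)(C)OC(=O)NCCCCNC(=O)CN1CN(c2ccccc2)C2(CCN(C(=O)c3ccc(C4CCCCC4)cc3)CC2)C1=O`: 4600 nM
Compound 2 `O=C(CN1CN(c2ccccc2)C2(CCN(C(=O)c3ccc(C4CCCCC4)cc3)CC2)C1=O)N1CCC(CO)CC1`: 1100 nM
Compound 3 `CS(=O)(=O)N1CCN(C(=O)CN2CN(c3ccccc3)C3(CCN(C(=O)c4ccc(C5CCCCC5)cc4)CC3)C2=O)CC1`: 6300 nM

In an assay on HEK293 cells for displacement of a labelled ligand from NPC1-like intracellular cholesterol transporter 1 (Homo sapiens) (a lower number here means a stronger inhibitor, a higher number a weaker inhibitor), compound 3 stands at the highest of the three numbers; compound 1 sits within the scatter of it, while compound 2 lies well below. Among the measured compounds shown here, the only step with a direct link was a 5.7-fold higher number from compound 2 to compound 3 (0.76 log units; beyond the scatter). Compound 4 `CS(=O)(=O)NCCNC(=O)CN1CN(c2ccccc2)C2(CCN(C(=O)c3ccc(C4CCCCC4)cc3)CC2)C1=O` arises from compound 3 through ((2-(methanesulfonamido)ethyl)amino in place of 4-(methylsulfonyl)piperazin-1-yl on a carbonyl carbon), so the ring is opened into a chain bearing two hydrogen-bond donors. For the measured compounds named here, no measured step covers that kind of change; compound 1, an open chain amide with a donor, shows a number close to compound 3, so the expectation is no step beyond the scatter, a 1.4-fold lower number from compound 3 to compound 4 (0.15 log units; within the scatter). Compound 4 is therefore expected at 4500 nM, with a range from 1500 nM to 14000 nM.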

Compound 4, half-maximal inhibitory concentration: 2100 nM
Beside the measured number, compound 4's estimate is 2.1-fold (0.33 log units) above it; the range from low to high includes it.
By their numbers in this assay, from the lowest: compounds 2 and 4 (each within the scatter of the next); then compounds 1 and 3 (each within the scatter of the next).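

In this assay, opening the 4-(methylsulfonyl)piperazin-1-yl ring into the (2-(methanesulfonamido)ethyl)amino chain gives a 3.0-fold lower number from compound 3 to compound 4 (0.48 log units; beyond the scatter), so this place on the carbonyl carbon needs no ring. The chain also holds up against a hydroxymethyl-bearing ring, with a 1.9-fold higher number from compound 2 to compound 4 (0.28 log units; within the scatter). Among open chains, the methanesulfonamido end improves on the 2-((tert-butoxycarbonyl)amino)ethyl end, with a 2.2-fold lower number from compound 1 to compound 4 (0.34 log units; beyond the scatter).

From the compounds shown here alone, whether a carboxylic acid or an amine at the chain end, or a longer chain, would lower the number further stays open. Nothing available explains what lies behind these steps.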